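Replacing a Fluorinated Chain with a Ring on Compound 3

A few compounds are considered here, and "the series" means these few. Any claim that something is new, unique, unknown or untested is made for them only; others in the source may bear on it.

Measured so far in a functional assay on HT-29 cells (Homo sapiens) for inhibition, read by luminescence and CellTiter-Glo, with a stated time of 24 h; a higher number here means that more compound is needed for the effect, a lower number that less compound is needed:
Compound 1 `CCCCn1nc(C(=O)N[C@H]2COc3ccccc3N(C)C2=S)nc1Cc1ccccc1` gives 510 nM.
Compound 2 `COCCn1nc(C(=O)N[C@H]2COc3ccccc3N(C)C2=S)nc1Cc1ccccc1` gives 566 nM.
Compound 3 `CN1C(=S)[C@@H](NC(=O)c2nc(Cc3ccccc3)n(CCC(F)(F)F)n2)COc2ccccc21` gives 1550 nM.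

Compound 3 stands highest of the three, so it needs the most compound for the effect: the steps of a 3.0-fold higher number from compound 1 to compound 3 (0.48 log units; beyond the scatter) and a 2.7-fold higher number from compound 2 to compound 3 (0.44 log units; beyond the scatter) both lie beyond the scatter, whereas the step of a 1.1-fold higher number from compound 1 to compound 2 (0.05 log units; within the scatter) lies within it. Compound 4 `CN1C(=S)[C@@H](NC(=O)c2nc(Cc3ccccc3)n(C3CCN(C(=O)OC(C)(C)C)C3)n2)COc2ccccc21` differs from compound 3 in one place: a group of 12 heavy atoms (9 carbon, 1 nitrogen, 2 oxygen; one five-membered non-aromatic ring with 1 hetero atom) in place of a group of 6 heavy atoms (3 carbon, 3 fluorine; no ring), on an aromatic nitrogen. The three measured steps all concern the tip of the chain on that aromatic nitrogen, where ethyl, methoxy and trifluoromethyl were exchanged, and they show only modest movement. None of them trades the whole 3,3,3-trifluoropropyl chain for a ring-bearing group of the size entering here, so they bear on the new step only loosely and give no firm direction in this assay. Compound 4 is therefore expected near compound 3, with wide uncertainty: an estimate of 1200 nM, ranging from 300 nM to 5000 nM, which means an expected step of a 1.3-fold lower number from compound 3 to compound 4 (0.11 log units; within the scatter).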

Compound 4, half-maximal effective concentration: > 10000 nM
Compound 4: a limit, no number; the forecaster's own chance of this, stated with the estimate: 10%; middle value at least 8.3-fold (0.92 log units) away from the limit.
By their numbers in this assay, from the lowest: compounds 1 and 2 (each within the scatter of the next); then compound 3. At a limit, above all of these: compound 4.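

In this assay, compound 4 gives a limit of the assay rather than a number: the limit of > 10000 nM in this assay, at which 1 of the 4 values shown sits. Exchanges at the tip of the chain moved the number only modestly, whereas replacing the whole chain on the aromatic nitrogen with the larger ring-bearing group gives an at least 6.4-fold higher number from compound 3 to compound 4 (0.80 log units; beyond the scatter), and the same kind of replacement gives an at least 17-fold higher number from compound 2 to compound 4 (1.24 log units; beyond the scatter) and an at least 19-fold higher number from compound 1 to compound 4 (1.29 log units; beyond the scatter). Among the compounds shown here, this position is therefore less forgiving than the earlier compounds suggested, since the group on this aromatic nitrogen can shift the result far more than those tip exchanges did.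

The ring and the rest of the entering group arrive together, so the compounds shown cannot tell which of them goes with the change. A plain cyclopentyl ring, or the same five-membered ring carrying a free amine, would help separate the two.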